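The source may report more compounds than this note shows. Statements on the series, on what has been measured and on what is new or still open speak of the compounds shown alone.

Measured compounds:
compound 1 `Cc1cccc(NC(=O)c2ccc(/N=N\c3c[nH]c4ccccc34)cc2)c1C` — 106000 nM
compound 2 `Cc1ccc(NC(=O)c2ccc(/N=N\c3c[nH]c4ccccc34)cc2)c(C)c1` — 87000 nM

In a functional assay on MCF7 cells (Homo sapiens) for inhibition, read by MTT assay, with a stated time of 72 h (on this read-out higher numbers stand for weaker inhibition and lower numbers for stronger inhibition), compound 2 gives 87000 nM, and compound 1 sits within the scatter of it, so the two cannot be told apart. Among the compounds with values here, the only measured step, a 1.2-fold lower number from compound 1 to compound 2 (0.09 log units; within the scatter), moved a methyl around the ring on the amide-type nitrogen and changed nothing beyond the scatter. Compound 3 `COc1ccccc1NC(=O)c1ccc(/N=N\c2c[nH]c3ccccc23)cc1` carries the change (2-methoxyphenyl in place of 2,4-dimethylphenyl on an amide-type nitrogen). Within the data shown here, that step touches the same ring, and the one comparable step was flat, so no shift beyond the scatter is expected. Compound 3 is expected at 90000 nM, between 30000 nM and 250000 nM. The estimated step is a 1.0-fold higher number from compound 2 to compound 3 (0.01 log units; within the scatter).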

Compound 3, half-maximal inhibitory concentration: 86500 nM
For compound 3 the middle estimate is 1.0-fold (0.02 log units) above the measured one, and the stated range covers the measured number.
By their numbers in this assay, from the lowest: compounds 3, 2 and 1 (each within the scatter of the next).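

With a 1.0-fold lower number from compound 2 to compound 3 (0.00 log units; within the scatter) and a 1.2-fold lower number from compound 1 to compound 3 (0.09 log units; within the scatter) in this assay the 2-methoxyphenyl group, which brings oxygen and a hydrogen-bond acceptor to the amide-type nitrogen, stays within the scatter of both dimethylphenyl groups. The earlier step only compared two dimethylphenyl groups, whereas this position has now taken a different kind of substituent with no shift beyond the scatter. Going by these compounds, whether an amine or a carboxylic acid on this ring, or a longer chain in place of it, would move the number remains open. No supporting measurement is available to explain the flat result.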